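Hydroxy in place of ethyl in compound 1

A few compounds are considered here, and "the series" means these few. Any claim that something is new, unique, unknown or untested is made for them only; others in the source may bear on it.

Among the measured compounds shown here, in a functional assay on the whole organism (stomach) with Rattus norvegicus as the target (a lower number here means that less compound is needed, a higher number that more compound is needed for the effect), compound 1 `CCCCCCCC/N=C/N1CCC(C(c2ccccc2)c2ccccc2)CC1` gives 3.9 mg/kg and holds the lower of the two numbers measured so far, with compound 2 `CC(=O)CCCCCC/N=C/N1CCC(C(c2ccccc2)c2ccccc2)CC1` at 10.5 mg/kg as its only neighbour. Compound 3 `OCCCCCC/N=C/N1CCC(C(c2ccccc2)c2ccccc2)CC1` is still unmeasured and carries hydroxy in place of ethyl on a saturated chain carbon, six bonds along the chain from a double-bonded nitrogen, which counts as hydroxy in place of ethyl on a saturated chain carbon, six bonds along the chain from a double-bonded nitrogen against the structure of compound 1. For the measured compounds named here, the one measured step at this place, acetyl in place of ethyl, is a 2.7-fold higher number from compound 1 to compound 2 (0.43 log units; beyond the scatter) and counts as modest. Going by the values given here, no hydroxy compound has been measured yet, so this step is only a loose guide. A step of similar size in the same direction, towards a higher number, is therefore expected in this assay and is estimated as a 2.3-fold higher number from compound 1 to compound 3 (0.36 log units; beyond the scatter) for now. Compound 3 is estimated at 9 mg/kg with an expected range from 3.5 mg/kg to 25 mg/kg for this measurement.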

Compound 3, dose for half-maximal effect: 11.2 mg/kg
Estimate against measurement, compound 3: 1.2-fold (0.09 log units) below, and the stated range covers the measured number.
By their numbers in this assay, from the lowest: compound 1; then compounds 2 and 3 (each within the scatter of the next).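

In this assay, a second replacement of the ethyl end of compound 1 also moves the number upward (a 2.9-fold higher number from compound 1 to compound 3 (0.46 log units; beyond the scatter)), so both changes measured at this place go the same way. Hydroxy and acetyl cannot be told apart here (a 1.1-fold higher number from compound 2 to compound 3 (0.03 log units; within the scatter)), which means that two different groups at the chain end give the same read-out within the scatter, and that compound 1 alone, with its plain alkyl chain, stays apart from them. Nothing on hand gives a reason for this shift.

On these data alone, whether an amine, a carboxylic acid or a longer plain alkyl chain at this place would read like compound 1 or like compound 2 and compound 3 stays open. So does whether a hydroxy group at the end of a longer chain would read like compound 3.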